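A few compounds are considered here, and "the series" means these few. Any claim that something is new, unique, unknown or untested is made for them only; others in the source may bear on it.

Measured compounds in an assay on isolated protein for displacement of a labelled ligand from melanin-concentrating hormone receptor 1 (Homo sapiens); on this read-out lower numbers stand for stronger inhibition and higher numbers for weaker inhibition:
compound 1 `CCCc1cc(NC2CC2)c2cc(NC(=O)/C=C/c3ccc(C(F)(F)F)cc3)ccc2n1`, 40 nM
compound 2 `CCCc1cc(N)c2cc(NC(=O)/C=C/c3ccc(Br)cc3)ccc2n1`, 4 nM
compound 3 `Nc1cc(C2CCC2)nc2ccc(NC(=O)/C=C/c3ccc(C(F)(F)F)cc3)cc12`, 2 nM

Compound 1 gives the highest number of the three; compound 2 sits one order lower and compound 3 lower still, both gaps beyond the scatter. No pair differs in one place only, so no step is shown.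

Compound 4 `CCCc1cc(N(C)C)c2cc(NC(=O)/C=C/c3ccc(C(F)(F)F)cc3)ccc2n1` is not yet measured. Its change from compound 1: dimethylamino in place of cyclopropylamino on an aromatic carbon. The shared core, the propyl group and the amide side are kept. Nothing measured tells how this change alone moves the read-out; the expectation is a step of a 1.1-fold lower number from compound 1 to compound 4 (0.06 log units; within the scatter) in this assay, lying within the scatter. Compound 4 is therefore estimated at 35 nM, with a range from 8 nM to 150 nM.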

Compound 4, half-maximal inhibitory concentration: 43 nM
For compound 4 the middle estimate is 1.2-fold (0.09 log units) below the measured one, and the stated range covers the measured number.
By their numbers in this assay, from the lowest: compounds 3 and 2 (each within the scatter of the next); then compounds 1 and 4 (each within the scatter of the next).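

In this assay, within the data shown here, dimethylamino in place of cyclopropylamino on an aromatic carbon opposite the ring nitrogen gives a 1.1-fold higher number from compound 1 to compound 4 (0.03 log units; within the scatter), the first one-place comparison. At this position, with the propyl group and the amide side kept, losing the three-membered ring and the hydrogen-bond donor leaves the number within the scatter. Nothing measured here accounts for this result.

Still open, going by these compounds, is how larger groups at this position behave, such as diethylamino or piperidine. On these data alone, a hydroxyl or methoxy group there is equally open.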